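Series notes: phenyl in place of thiophen-3-yl

This account rests on a few compounds, and the source may have more. Where it says the series, first, only, none or still open, it means among the compounds named here.

Compound 1, `COC(=O)c1sc2cc(C#Cc3ccccc3OC)cnc2c1N`: in a functional assay on NCI-H460 cells (Homo sapiens) for inhibition, read by sulforhodamine B assay, with a stated time of 48 h (on this read-out lower numbers stand for stronger inhibition of growth and higher numbers for weaker inhibition of growth), compound 1 gives only a limit of the assay, > 47300 nM.
Compound 2, `COC(=O)c1sc2cc(C#Cc3ccccc3F)cnc2c1N`: compound 2 likewise gives only a limit, > 150000 nM.
Compound 3, `COC(=O)c1sc2cc(C#Cc3ccsc3)cnc2c1N`: compound 3 gives 24800 nM.

Among the measured compounds shown here, compound 3 holds the only number in this assay; the two other values are limits. The step of an at least 1.9-fold lower number from compound 1 to compound 3 (0.28 log units; that floor lies within the scatter) and the step of an at least 6.0-fold lower number from compound 2 to compound 3 (0.78 log units; beyond the scatter) both run from a six-membered aromatic ring to thiophen-3-yl on the triple-bonded carbon and both lower the number, the second one clearly. The step that the two limits leave unreadable from compound 1 to compound 2 cannot be read, as both its ends are limits.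

Compound 4, `COC(=O)c1sc2cc(C#Cc3ccccc3)cnc2c1N`, is still to be measured. Its change from compound 3: phenyl in place of thiophen-3-yl on a triple-bonded carbon. This runs in the opposite sense to the two readable steps, back onto a six-membered ring of carbon only, so a higher number than compound 3 is expected. Compound 1 and compound 2 each carry a methoxy or a fluoro on that ring, which compound 4 lacks, so the expected rise is kept modest, with a real chance of only a limit.

Compound 4 is therefore expected to give 40000 nM, with a range of 15000 nM to 120000 nM. This estimate means the step of a 1.6-fold higher number from compound 3 to compound 4 (0.21 log units; within the scatter).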

Compound 4, concentration for 50% growth inhibition: > 150000 nM
Compound 4: no number, only a limit; the forecaster's own chance of this, stated with the estimate: 35%; middle value at least 3.7-fold (0.57 log units) away from the limit.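

In this assay, phenyl in place of thiophen-3-yl on the triple-bonded carbon gives an at least 6.0-fold higher number from compound 3 to compound 4 (0.78 log units; beyond the scatter). The earlier six-membered rings all carried a methoxy or a fluoro, so it remained unclear whether those groups accounted for the gap to compound 3; compound 4 carries neither and still stands clearly apart from compound 3, so at this position the gap does not need either group. The steps from compound 1 and from compound 2 to compound 4 cannot be read, so the hydrogen cannot be ranked against the methoxy or the fluoro on that ring, and the upper limit of the assay gives no order among them: the limit of > 150000 nM in this assay, at which 2 of the 4 values shown sit.

The compounds shown do not separate the sulfur of thiophen-3-yl from the five-membered ring itself, which thiophen-2-yl, furan-3-yl or pyridin-3-yl on the triple-bonded carbon could begin to address. They also leave open whether an amine or a carboxylic acid on the phenyl, or a longer chain in place of the ring, would give a measurable number alongside compound 3, at 24800 nM.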